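This account rests on a few compounds, and the source may have more. Where it says the series, first, only, none or still open, it means among the compounds named here.

Measured so far:
compound 1 `COc1cc(-c2ccnc3cc(-c4ccc(C)cc4)nn23)cc(OC)c1OC` — 48 nM
compound 2 `COc1cc(-c2ccnc3cc(-c4ccc(Cl)cc4)nn23)cc(OC)c1OC` — 3340 nM
compound 3 `COc1cc(-c2ccnc3cc(-c4ccc5cnn(C)c5c4)nn23)cc(OC)c1OC` — 2440 nM

In a functional assay on HCT-116 cells (Homo sapiens) for inhibition, read by CCK-8 assay, with a stated time of 48 h (a higher number here means a weaker inhibitor, a lower number a stronger inhibitor), compound 3 stands second highest of the three, close to compound 2 and far from compound 1. Compound 4 `COc1ccc(-c2cc3nccc(-c4cc(OC)c(OC)c(OC)c4)n3n2)cc1` differs from compound 3 by 4-methoxyphenyl in place of 1-methyl-1H-indazol-6-yl on an aromatic carbon. Within the data shown here, two steps bear on this: a 51-fold higher number from compound 1 to compound 3 (1.71 log units; beyond the scatter), where a substituted phenyl gave the much lower number, and a 1.4-fold lower number from compound 2 to compound 3 (0.14 log units; within the scatter), where a differently substituted phenyl sat level with compound 3. Among the measured compounds shown here, the gap a 70-fold higher number from compound 1 to compound 2 (1.84 log units; beyond the scatter) shows the substituent on the phenyl decides the outcome, and methoxy has no precedent here. For compound 4 a lower number is expected, though the size is uncertain: the estimated step is a 4.1-fold lower number from compound 3 to compound 4 (0.61 log units; beyond the scatter). Compound 4 is estimated at 600 nM, within 60 nM to 4000 nM.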

Compound 4, half-maximal inhibitory concentration: 404 nM
The estimate for compound 4 lay 1.5-fold (0.17 log units) above the measured number, within the range that was stated.
By their numbers in this assay, from the lowest: compound 1; then compound 4; then compounds 3 and 2 (each within the scatter of the next).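

In this assay, 4-methoxyphenyl at this position outdoes 1-methyl-1H-indazol-6-yl (a 6.0-fold lower number from compound 3 to compound 4 (0.78 log units; beyond the scatter)), so the gap between compound 1 and compound 3 does not close the position to all other groups. On the phenyl, methoxy gives a level of its own, better than chloro (an 8.3-fold lower number from compound 2 to compound 4 (0.92 log units; beyond the scatter)) yet worse than methyl (an 8.4-fold higher number from compound 1 to compound 4 (0.93 log units; beyond the scatter)), so the three substituents fall on three separate levels. Nothing available explains this order. On these data alone, whether a longer chain such as ethyl holds the low number of methyl remains open, as does the outcome with an amine or a carboxylic acid on the phenyl.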